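The source may report more compounds than this note shows. Statements on the series, on what has been measured and on what is new or still open speak of the compounds shown alone.

The measured compounds:

compound 1, `CSc1ncnc2c1c(-c1ccccc1)cn2[C@@H]1O[C@H](CO)[C@@H](O)[C@H]1O`: in an ADME assay on BJ cells (Homo sapiens), read by MTT assay, with a stated time of 72 h (a higher number here means a weaker inhibitor, a lower number a stronger inhibitor), compound 1 gives > 100000 nM, which is a limit of the assay rather than a number.

compound 2, `CNc1ncnc2c1c(-c1ccccc1)cn2[C@@H]1O[C@H](CO)[C@@H](O)[C@H]1O`: in this assay compound 2 gives > 100000 nM, again a limit and not a number.

Compound 2 therefore stands at the ceiling of what this assay reports. Within the data shown here, the only measured step, a step that the two limits leave unreadable from compound 1 to compound 2, cannot be read in size or direction, since both ends sit at the limit; this is summed up by the limit of > 100000 nM in this assay, at which 2 of the 2 values shown sit.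

Compound 3, `CNc1ncnc2c1c(-c1ccco1)cn2[C@@H]1O[C@H](CO)[C@@H](O)[C@H]1O`, is compound 2 with furan-2-yl in place of phenyl on an aromatic carbon. Among the measured compounds shown here, no measured step touches this part of the core, and the single step that is known is unreadable, so nothing in the data points to a change beyond the usual scatter in either direction. Compound 3 is accordingly expected to remain at or near the limit, with an estimated step that the limit leaves unreadable from compound 2 to compound 3. The estimate for compound 3 in this assay is 150000 nM, within a range from 20000 nM to 1000000 nM.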

Compound 3, half-maximal inhibitory concentration: 5040 nM
Compound 3: middle estimate off by 30-fold (1.47 log units), on the high side, and the stated range ends above it.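

Among these compounds, exchanging phenyl for furan-2-yl gives an at least 19-fold lower number from compound 2 to compound 3 (1.29 log units; beyond the scatter), so this position, which no earlier step touched, can move the read-out in this assay. Compound 3 is the first compound shown with a number rather than a limit, and the printed size of the step is only a lower bound. Compound 1 and compound 2 both remain at a limit of the assay: the limit of > 100000 nM in this assay, at which 2 of the 3 values shown sit.

Going by these compounds, it remains open whether the step follows from the ring oxygen or from the smaller ring, and whether a thiophen-2-yl or a furan-3-yl group at this position would give a comparable number. Among the compounds shown here, also open is whether methylsulfanyl in place of methylamino would matter with furan-2-yl present, as the one step between these two groups cannot be read.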